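A few compounds are considered here, and "the series" means these few. Any claim that something is new, unique, unknown or untested is made for them only; others in the source may bear on it.

Measured compounds in a functional assay on MCF7 cells (Homo sapiens) for inhibition; on this read-out higher numbers stand for weaker inhibition and lower numbers for stronger inhibition:
Compound 1, `CC/C(=C(/c1ccc(/C=C/C(=O)O)cc1)c1cc2ccccc2[nH]1)c1ccccc1C(F)(F)F`, gives 8 nM.
Compound 2, `CC/C(=C(/c1ccc(/C=C/C(=O)O)cc1)c1cc2ccccc2[nH]1)c1cccc(C)c1`, gives 140 nM.

For the measured compounds named here, compound 2 holds the highest of the two numbers in this assay; its only neighbour is compound 1, and the step of an 18-fold higher number from compound 1 to compound 2 (1.24 log units; beyond the scatter) separates them. That step changed both the group on the phenyl ring and where it sits, so it shows only that this part of the molecule can matter a great deal.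

Compound 3, `CC/C(=C(/c1ccc(/C=C/C(=O)O)cc1)c1cc2ccccc2[nH]1)c1cccc(OC(F)(F)F)c1`, is the next one to be measured. The change from compound 2 is trifluoromethoxy in place of methyl on an aromatic carbon. Going by the values given here, no measured pair changes a group at this position on this ring while leaving everything else alone, so the single step from compound 1 to compound 2 bears on it only loosely.

Compound 3 is therefore estimated at 80 nM in this assay, within a range of 20 nM to 400 nM. This means a step of a 1.8-fold lower number from compound 2 to compound 3 (0.24 log units; within the scatter) is expected, which stays within the usual scatter of repeated measurements.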

Compound 3, half-maximal inhibitory concentration: 282 nM
Beside the measured number, compound 3's estimate is 3.5-fold (0.55 log units) below it, within the range that was stated.
By their numbers in this assay, from the lowest: compound 1; then compounds 2 and 3 (each within the scatter of the next).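

In this assay, replacing methyl (1 heavy atom) with trifluoromethoxy (5 heavy atoms) on this aromatic carbon, meta to a large group, gives a 2.0-fold higher number from compound 2 to compound 3 (0.30 log units; within the scatter). The two groups therefore cannot be told apart here, so at this carbon the read-out does not separate these two groups despite their difference in atom count. The other new step, a 35-fold higher number from compound 1 to compound 3 (1.55 log units; beyond the scatter), is large, and together with an 18-fold higher number from compound 1 to compound 2 (1.24 log units; beyond the scatter) it shows that compound 1 stands apart from both compounds carrying a group at this carbon, so the gap no longer rests on a single comparison. Nothing available explains why these numbers fall as they do.

On these data alone, what stays open is whether compound 1 owes its number to the trifluoromethyl group itself or to where that group sits on the ring, since every step from compound 1 changes both at once. Placing trifluoromethyl on the carbon that holds methyl in compound 2 would separate the two, and an amine or a carboxylic acid at that carbon would test whether this position stays as indifferent to groups of quite another kind.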